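Ethyl in Place of Bromo: From Compound 3 to Compound 4

This account rests on a few compounds, and the source may have more. Where it says the series, first, only, none or still open, it means among the compounds named here.

Compound 1 `O=C1C(N2CCCCC2)=CC(=O)c2c1nc1n2[C@H]2OC[C@@H](O)[C@H]2OC1`: > 16000 nM, a limit of the assay.
Compound 2 `O=C1C(NC2CCCC2)=CC(=O)c2c1nc1n2[C@H]2OC[C@@H](O)[C@H]2OC1`: > 16000 nM, a limit of the assay.
Compound 3 `O=C1C(Nc2ccc(Br)cc2)=CC(=O)c2c1nc1n2[C@H]2OC[C@@H](O)[C@H]2OC1`: 5220 nM.
Compound 4 `CCc1ccc(NC2=CC(=O)c3c(nc4n3[C@H]3OC[C@@H](O)[C@H]3OC4)C2=O)cc1`: not yet measured.

For the measured compounds named here, in a functional assay on HeLa cells (Homo sapiens) for inhibition, read by sulforhodamine B assay (on this read-out lower numbers stand for stronger inhibition and higher numbers for weaker inhibition), compound 3 gives 5220 nM, the only number among the three measured compounds. The values of compound 1 and compound 2 are limits of the assay, as the limit of > 16000 nM in this assay, at which 2 of the 3 values shown sit, shows. The step of an at least 3.0-fold lower number from compound 1 to compound 3 (0.48 log units; beyond the scatter) and the step of an at least 3.0-fold lower number from compound 2 to compound 3 (0.48 log units; beyond the scatter) both point the same way, with the (4-bromophenyl)amino group giving a lower number than either cyclic amine. The step that the two limits leave unreadable from compound 1 to compound 2 cannot be read.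

Compound 4 differs from compound 3 by ethyl in place of bromo on an aromatic carbon. No measured step touches the group on the six-membered aromatic ring itself, so the direction of this change is not anchored by the shown data; the steps to compound 3 only establish that an aryl amine on the double-bonded ring carbon is what brings the number down. Compound 4 is therefore expected to stay near compound 3, with a step of a 1.0-fold lower number from compound 3 to compound 4 (0.02 log units; within the scatter) that lies within the scatter, and its value in this assay is estimated at 5000 nM, between 1500 nM and 16000 nM.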

Compound 4, half-maximal inhibitory concentration: 6510 nM
Beside the measured number, compound 4's estimate is 1.3-fold (0.11 log units) below it; low and high end bracket the measured number.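

In this assay the exchange of bromo for ethyl on the six-membered aromatic ring gives a 1.2-fold higher number from compound 3 to compound 4 (0.10 log units; within the scatter) and is the first change shown on that ring itself, para to a large group; it leaves the read-out within the scatter. The lower number seen with the (4-bromophenyl)amino group is thus not tied to bromo: the (4-ethylphenyl)amino group in place of piperidin-1-yl gives an at least 2.4-fold lower number from compound 1 to compound 4 (0.39 log units; beyond the scatter) and 4-ethylphenyl in place of cyclopentyl on the amine nitrogen gives an at least 2.4-fold lower number from compound 2 to compound 4 (0.39 log units; beyond the scatter) in the same assay. The values of compound 1 and compound 2 are limits of the assay and not numbers, so these two steps are bounds only: the limit of > 16000 nM in this assay, at which 2 of the 4 values shown sit.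

Bromo and ethyl both carry no hydrogen-bond donors or acceptors and no net charge, so the compounds shown leave open what an amine, a hydroxyl or a carboxylic acid would do in this place. They also leave open whether a plain phenyl without any group, or a longer chain such as butyl on the ring, would stay level with compound 3 and compound 4.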